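Moving the Furan Attachment on a Shared Nucleoside Core

The source may hold more compounds than are shown below. What is called first, only, known or untested is meant among the compounds shown, and "the series" means these compounds.

In an ADME assay on BJ cells (Homo sapiens), read by MTT assay, with a stated time of 72 h (on this read-out lower numbers stand for stronger inhibition and higher numbers for weaker inhibition), compound 1 `Nc1nc2c(c(-c3ccco3)cn2[C@@H]2O[C@H](CO)[C@@H](O)[C@H]2O)c(=O)[nH]1` gives > 100000 nM, which is a limit of the assay rather than a number. Compound 2 `O=c1[nH]cnc2c1c(-c1ccco1)cn2[C@@H]1O[C@H](CO)[C@@H](O)[C@H]1O` gives > 100000 nM, again a limit. Compound 3 `C#Cc1cn([C@@H]2O[C@H](CO)[C@@H](O)[C@H]2O)c2nc(C)nc(N)c12` likewise sits at a limit, > 100000 nM. Going by the values given here, the only one-place step between measured compounds, a step that the two limits leave unreadable from compound 1 to compound 2, cannot be read because of the limit of > 100000 nM in this assay, at which 3 of the 3 values shown sit. Compound 4 `Nc1nc2c(c(-c3ccoc3)cn2[C@@H]2O[C@H](CO)[C@@H](O)[C@H]2O)c(=O)[nH]1` differs from compound 1 by furan-3-yl in place of furan-2-yl on an aromatic carbon. Among the compounds with values here, no measured step bears on this change, and every value shown is a limit, so no readable step is expected: compound 4 is estimated to remain at the limit, and the step that the limit leaves unreadable from compound 1 to compound 4 is expected to be unreadable. Compound 4 is therefore expected near 150000 nM, within 50000 nM to 500000 nM.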

Compound 4, half-maximal inhibitory concentration: 21500 nM
Compound 4: middle estimate off by 7.0-fold (0.84 log units), on the high side, outside the stated range (below it).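

In this assay, going by these compounds alone, moving the furan attachment gives the first readable step in this set: an at least 4.6-fold lower number from compound 1 to compound 4 (0.66 log units; beyond the scatter). With the same atoms joined differently, furan-3-yl on this aromatic carbon gives a real number where furan-2-yl on the same core gives only a limit. The earlier step cannot be read, because of a shared limit: the limit of > 100000 nM in this assay, at which 3 of the 4 values shown sit.

Within the data shown here, only this one pair bears on the change, so whether furan-3-yl would act alike on the core of compound 2, which lacks the amino group, stays open. From the compounds shown here alone, how a thiophen-3-yl or phenyl group on this carbon would read also stays open.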